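Sulfur-linked aryl swap on the compound 1 core

A few compounds are considered here, and "the series" means these few. Any claim that something is new, unique, unknown or untested is made for them only; others in the source may bear on it.

Measured compounds:
compound 1 `CS(=O)(=O)c1ccc(-c2nc3ccccn3c2Sc2ccccc2)cc1` — 23200 nM
compound 2 `CCc1ccc(-c2nc3ccccn3c2Sc2ccccc2)cc1` — 56200 nM
compound 3 `N#Cc1ccc(-c2nc3ccccn3c2Sc2ccccc2)cc1` — 35200 nM

In a functional assay on A549 cells (Homo sapiens) for inhibition, read by MTT assay, with a stated time of 48 h (on this read-out lower numbers stand for stronger inhibition and higher numbers for weaker inhibition), compound 1 gives the lowest of the three numbers. Its nearest neighbour is compound 3, with a 1.5-fold higher number from compound 1 to compound 3 (0.18 log units; within the scatter), a difference inside the usual scatter, so no order between compound 1 and compound 3 can be claimed. Compound 2 stands further off, with a 2.4-fold higher number from compound 1 to compound 2 (0.38 log units; beyond the scatter); between compound 2 and compound 3 the step is a 1.6-fold lower number from compound 2 to compound 3 (0.20 log units; within the scatter).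

Compound 4 `CS(=O)(=O)c1ccc(-c2nc3ccccn3c2Sc2cccc3ccccc23)cc1` differs from compound 1 by naphthalen-1-yl in place of phenyl on a sulfur. Among the compounds with values here, all three measured steps change the group on the aromatic carbon of the pendant ring; none touches the aryl group on the sulfur, so no measured step bears directly on this change. The measured steps are modest at most, and nothing in the series points either way for the sulfur-linked aryl. Compound 4 is therefore expected to sit near compound 1 in this assay, with a 1.1-fold lower number from compound 1 to compound 4 (0.02 log units; within the scatter) as the estimated step and no shift beyond the scatter. The estimate for compound 4 in this assay is 22000 nM, with a range from 7000 nM to 70000 nM.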

Compound 4, half-maximal inhibitory concentration: 19600 nM
The estimate for compound 4 lay 1.1-fold (0.05 log units) above the measured number; the range from low to high includes it.
By their numbers in this assay, from the lowest: compounds 4, 1, 3 and 2 (each within the scatter of the next, the first and the last beyond it).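

In this assay, the only change shown to the aryl group on a sulfur gives a 1.2-fold lower number from compound 1 to compound 4 (0.07 log units; within the scatter). Naphthalen-1-yl, with its second six-membered aromatic ring of carbon only, therefore cannot be told apart from phenyl at this position, at least in this single pair with methylsulfonyl kept in place. No measured property of either group accompanies this result, and the data offer no explanation for it.

On these data alone, it remains open whether the number at this position would move with a phenyl carrying an amine or a carboxylic acid, or with a methyl group or longer alkyl chain in place of the aryl group on the sulfur. Also open, as far as these compounds go, is whether naphthalen-1-yl behaves the same way with ethyl or cyano in place of methylsulfonyl.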